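Cytotoxicity of two sulfonamide benzamide pairs in macrophage cells

A few compounds are considered here, and "the series" means these few. Any claim that something is new, unique, unknown or untested is made for them only; others in the source may bear on it.

Compound 1, `Cc1cc(NC(=O)c2cc(C(F)(F)F)cc(C(F)(F)F)c2)ccc1NS(C)(=O)=O`: > 250000 nM
Compound 2, `CCS(=O)(=O)Nc1ccc(NC(=O)c2cc(C(F)(F)F)cc(C(F)(F)F)c2)cc1C`: 124000 nM
Compound 3, `COc1cc(NC(=O)c2ccc(Cl)cc2)ccc1NS(C)(=O)=O`: 70000 nM

Of the compounds shown here, three have been measured in an ADME assay on RAW264.7 cells (Mus musculus) for cytotoxicity, read by MTT assay, with a stated time of 48 h; a higher number here means a weaker inhibitor, a lower number a stronger inhibitor. For compound 1 the result is a limit of this assay, > 250000 nM, and not a number; (the limit of > 250000 nM in this assay, at which 1 of the 3 values shown sits). Compound 2 gives 124000 nM, and compound 3 gives 70000 nM. The change from compound 1 to compound 2 is methyl in place of hydrogen on a saturated chain carbon bound to a sulfonyl sulfur, and in this assay it made an at least 2.0-fold lower number from compound 1 to compound 2 (0.30 log units; that floor lies within the scatter).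

Compound 4, `CCS(=O)(=O)Nc1ccc(NC(=O)c2ccc(Cl)cc2)cc1OC`, has not yet been measured. It differs from compound 3 by methyl in place of hydrogen on a saturated chain carbon bound to a sulfonyl sulfur, the same change as that from compound 1 to compound 2. The difference between the core of compound 3 and the core of compound 1 is not broken down here.

Because of an at least 2.0-fold lower number from compound 1 to compound 2 (0.30 log units; that floor lies within the scatter), the step from compound 3 to compound 4 is expected to be a 1.6-fold lower number from compound 3 to compound 4 (0.19 log units; within the scatter) in this assay. On that basis compound 4 is estimated to give 45000 nM, with a range from 20000 nM to 100000 nM expected.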

Compound 4, half-maximal inhibitory concentration: 60100 nM
The estimate for compound 4 lay 1.3-fold (0.13 log units) below the measured number; measured number inside the range.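

In this assay, methyl in place of hydrogen on a saturated chain carbon bound to a sulfonyl sulfur, which turns methylsulfonyl into ethylsulfonyl, gave a 1.2-fold lower number from compound 3 to compound 4 (0.07 log units; within the scatter). On the earlier pair, compound 1 gives > 250000 nM, which is a limit of the assay and not a number, so the size of its step is not fixed. On the core of compound 3 the change stays within the scatter, but these data do not show whether it carries over from the core of compound 1 with the same size: the same change on two cores in this assay, an at least 2.0-fold lower number (0.30 log units; that floor lies within the scatter) from compound 1 to compound 2 and a 1.2-fold lower number (0.07 log units; within the scatter) from compound 3 to compound 4; the limit leaves it open whether they differ.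

The compounds shown leave open whether a longer chain on the sulfonyl group, such as propyl or butyl, would move the number in this assay beyond the scatter. They also leave open how the same change from methylsulfonyl to ethylsulfonyl would read on a further core, for example one carrying an amine or a carboxylic acid.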